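The compounds below may be only part of what the source reports. "The series", "measured", "known", "first", "only" and "open" are said of these compounds alone.

Four compounds share one core. Compound 1 `COC(=O)C1=C(C)NC(=O)NC1c1ccoc1` and compound 2 `CCCOC(=O)C1=C(C)NC(=O)NC1c1ccoc1` differ in a single place, (ethyl in place of hydrogen on a saturated chain carbon bound to an oxygen next to a carbonyl group). In an assay on membranes from CHO cells for displacement of a labelled ligand from adenosine receptor A1 (Homo sapiens), read by scintillation counting, with a stated time of 60 min, tested at 1 uM (on this read-out higher numbers stand for more inhibition at the one concentration tested (going by the name of the read-out) and lower numbers for less inhibition), compound 1 gives 8% and compound 2 gives 50%, a step of a number 42 percentage points higher from compound 1 to compound 2 (beyond the scatter). Compound 3 `COC(=O)C1=C(C)NC(=S)NC1c1ccoc1` gives 25% in this assay; the difference between the cores of compound 1 and compound 3 is not broken down here. Compound 4 `CCCOC(=O)C1=C(C)NC(=S)NC1c1ccoc1` carries the same change on the core of compound 3, (ethyl in place of hydrogen on a saturated chain carbon bound to an oxygen next to a carbonyl group), at a place described in the same words as before. Going by the values given here, only one measured instance of this change exists, so the expectation rests on it alone, carried over to compound 3. In this assay the expected step is a number 37 percentage points higher from compound 3 to compound 4 (beyond the scatter), resting on a number 42 percentage points higher from compound 1 to compound 2 (beyond the scatter) and taken as close in size to it. The estimate for compound 4 is 62%, with a range from 40% to 84%.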

Compound 4, a percentage reported as inhibition, at one concentration (the size of the read-out at that concentration, not a potency): 4%
Beside the measured number, compound 4's estimate is 58 percentage points above it; the measured number lies below the stated range.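

In this assay, methoxycarbonyl to propoxycarbonyl gives a number 21 percentage points lower from compound 3 to compound 4 (beyond the scatter). The same change therefore moves the read-out in opposite directions on the two cores: the same change on two cores in this assay, a number 42 percentage points higher (beyond the scatter) from compound 1 to compound 2 and a number 21 percentage points lower (beyond the scatter) from compound 3 to compound 4, 63 percentage points apart, beyond the scatter of two such steps

In this series, a step measured on one core does not carry over to the other, in size or in direction; with a single pair on each core, this does not show which difference between the cores lies behind the reversal, or how the change would behave on any further core. The compounds shown leave open how an ethoxycarbonyl or a longer chain such as butoxycarbonyl would read on either core. From the compounds shown here alone, a carboxylic acid in the same place also remains open.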